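The source may report more compounds than this note shows. Statements on the series, on what has been measured and on what is new or still open speak of the compounds shown alone.

Working notes on the series built around the core of compound 1 `c1cc2cc(-c3nc(N4CC5CCC(C4)O5)c4sccc4n3)ccc2[nH]1`. In a functional assay on LNCaP cells (Homo sapiens) for cytotoxicity (a lower number here means a stronger inhibitor, a higher number a weaker inhibitor), compound 1 gives 1350 nM. Compound 2 `O=C(Nc1ccncc1)Nc1ccc(-c2nc(N3CC4CCC(C3)O4)c3sccc3n2)cc1` gives 10 nM in this assay, and compound 3 `COC(=O)Nc1ccc(-c2nc(N3CC4CCC(C3)O4)c3sccc3n2)cc1` gives 1850 nM in this assay. Among the three measured numbers compound 3 stands highest; compound 1 is nearest to it, the two lying within the scatter of each other, while compound 2 is furthest away. The size of that gap is the step of a 190-fold higher number from compound 2 to compound 3 (2.27 log units; beyond the scatter).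

Compound 4 `O=C(Nc1ccc(-c2nc(N3CC4CCC(C3)O4)c3sccc3n2)cc1)NC1CC1` is not yet measured. Relative to compound 3 the change is cyclopropylamino in place of methoxy on a carbonyl carbon. Within the data shown here, one measured step bears on this: a 190-fold higher number from compound 2 to compound 3 (2.27 log units; beyond the scatter), which removed an amino substituent from the same carbonyl carbon and left methoxy there. The step to compound 4 puts an amino substituent back on that carbonyl carbon, cyclopropylamino rather than (pyridin-4-yl)amino, so a large move in this assay toward lower numbers is expected, though whether cyclopropylamino recovers all of what (pyridin-4-yl)amino gave in compound 2 cannot be told from a single step. The step expected here is a 31-fold lower number from compound 3 to compound 4 (1.49 log units; beyond the scatter). For compound 4 the estimate in this assay is 60 nM, with a range from 12 nM to 300 nM.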

Compound 4, half-maximal inhibitory concentration: 40 nM
Compound 4: the middle estimate sits 1.5-fold (0.18 log units) above what was measured; measured number inside the range.
By their numbers in this assay, from the lowest: compound 2; then compound 4; then compounds 1 and 3 (each within the scatter of the next).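

The step to compound 4, a 46-fold lower number from compound 3 to compound 4 (1.67 log units; beyond the scatter), shows that the large sensitivity of this carbonyl carbon in this assay does not depend on the pyridin-4-yl group, since a cyclopropylamino substituent, with its one three-membered non-aromatic ring of carbon only, recovers most of the ground lost with methoxy. The group on the amide-type nitrogen still counts, but on a smaller scale: a 4.0-fold higher number from compound 2 to compound 4 (0.60 log units; beyond the scatter) is modest, though beyond the scatter, so the choice between cyclopropyl and pyridin-4-yl matters far less in these compounds than the choice between methoxy and an amino substituent. No supporting data on mechanism or properties bear on these steps, so the difference between methoxy and the amino substituents remains a bare observation.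

The compounds shown leave open whether the amide hydrogen is needed, which a dimethylamino group on the same carbonyl carbon would test directly. They also leave open how far the nitrogen substituent can vary, for instance with a phenyl ring, a pyridin-3-yl ring or a longer chain such as n-butyl in place of cyclopropyl.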